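Methoxy for Chloro on the Sulfonyl Aryl Ring

The compounds below may be only part of what the source reports. "The series", "measured", "known", "first", "only" and "open" are said of these compounds alone.

Within the data shown here, in a functional assay on aorta for antagonist activity at thromboxane A2 receptor (Rattus norvegicus) (a higher number here means weaker binding, a lower number tighter binding), compound 2 `O=C(O)CCn1cc(Cc2ccc(F)cc2)c2cc(NS(=O)(=O)c3ccc(Cl)cc3)ccc21` gives 0.234 nM, the lowest of the two numbers measured so far. Its nearest neighbour is compound 1 `O=C(O)CCn1ccc2cc(NS(=O)(=O)c3ccc(Cl)cc3)ccc21`, which in this assay gives 2.75 nM; the step of a 12-fold lower number from compound 1 to compound 2 (1.07 log units; beyond the scatter) came from 4-fluorobenzyl in place of hydrogen on an aromatic carbon. Compound 3 `COc1ccc(S(=O)(=O)Nc2ccc3c(c2)c(Cc2ccc(F)cc2)cn3CCC(=O)O)cc1` differs from compound 2 elsewhere: methoxy in place of chloro on an aromatic carbon. Among the measured compounds shown here, no measured step touches the (4-chlorophenyl)sulfonyl group, so the single step available, a 12-fold lower number from compound 1 to compound 2 (1.07 log units; beyond the scatter), bears on compound 3 only indirectly, showing how far one change can move the number. Without a direct precedent, compound 3 is expected to remain near compound 2, with an estimated step of a 1.7-fold higher number from compound 2 to compound 3 (0.23 log units; within the scatter), not clearly beyond the scatter. The expected value for compound 3 is 0.4 nM, within an estimated range of 0.1 nM to 2 nM.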

Compound 3, dissociation constant: 0.174 nM
Compound 3: the middle estimate sits 2.3-fold (0.36 log units) above what was measured; low and high end bracket the measured number.
By their numbers in this assay, from the lowest: compounds 3 and 2 (each within the scatter of the next); then compound 1.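

Among these compounds, this is the first measured change on the sulfonyl aryl ring, and methoxy in place of chloro gives a 1.3-fold lower number from compound 2 to compound 3 (0.13 log units; within the scatter) in this assay. At this place, para to a large group, a chlorine can thus give way to a methoxy group, with its added heavy atom and hydrogen-bond acceptor, and the low number reached with the 4-fluorobenzyl group is kept. No evidence on either group accompanies this result.

As far as these compounds go, whether an amine, a carboxylic acid or a longer chain such as ethoxy would hold the number at this place remains open. So does whether the same change would leave the number unmoved on the core of compound 1, which lacks the 4-fluorobenzyl group.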